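Chloro for Fluoro on the Sulfonyl Aryl Ring

The source may report more compounds than this note shows. Statements on the series, on what has been measured and on what is new or still open speak of the compounds shown alone.

Three compounds on a shared core were measured in a functional assay on HepG2 cells (Homo sapiens) for antiproliferative activity, read by MTT assay, with a stated time of 24 h; a higher number here means a weaker inhibitor, a lower number a stronger inhibitor. Compound 1 `Cc1ccc(-c2nn(-c3ccccc3)cc2-c2nc3ccccc3n2S(=O)(=O)c2ccc(F)cc2)cc1` gives 5060 nM. Compound 2 `Cc1ccc(-c2nn(-c3ccccc3)cc2-c2nc3ccccc3n2S(=O)(=O)c2ccc(Cl)cc2)cc1` carries chloro in place of fluoro on an aromatic carbon and gives 5520 nM; the step is a 1.1-fold higher number from compound 1 to compound 2 (0.04 log units; within the scatter). Compound 3 `O=S(=O)(c1ccc(F)cc1)n1c(-c2cn(-c3ccccc3)nc2-c2ccc(C(F)(F)F)cc2)nc2ccccc21` differs from compound 1 by trifluoromethyl in place of methyl on an aromatic carbon; compound 3 gives 2730 nM, with a 1.9-fold lower number from compound 1 to compound 3 (0.27 log units; within the scatter); its numbers against compound 1 and compound 2 are close, and no ordering is claimed.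

Compound 4 `O=S(=O)(c1ccc(Cl)cc1)n1c(-c2cn(-c3ccccc3)nc2-c2ccc(C(F)(F)F)cc2)nc2ccccc21` is not yet measured. It differs from compound 3 by chloro in place of fluoro on an aromatic carbon, the same change, at the same place, that separates compound 2 from compound 1. Because that change once gave a 1.1-fold higher number from compound 1 to compound 2 (0.04 log units; within the scatter), the expected step is a 1.1-fold higher number from compound 3 to compound 4 (0.04 log units; within the scatter). Compound 4 is therefore estimated at 3000 nM, with a range from 1500 nM to 6500 nM in this assay.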

Compound 4, half-maximal inhibitory concentration: 3930 nM
For compound 4 the middle estimate is 1.3-fold (0.12 log units) below the measured one; the measured number falls inside the stated range.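

In this assay, chloro in place of fluoro gives a 1.4-fold higher number from compound 3 to compound 4 (0.16 log units; within the scatter), and the change reads alike on both cores: the same change on two cores in this assay, a 1.1-fold higher number (0.04 log units; within the scatter) from compound 1 to compound 2 and a 1.4-fold higher number (0.16 log units; within the scatter) from compound 3 to compound 4, 1.3-fold (0.12 log units) apart, within the scatter of two such steps. Trifluoromethyl in place of methyl gives a 1.4-fold lower number from compound 2 to compound 4 (0.15 log units; within the scatter), and this change also reads alike on both cores: the same change on two cores in this assay, a 1.9-fold lower number (0.27 log units; within the scatter) from compound 1 to compound 3 and a 1.4-fold lower number (0.15 log units; within the scatter) from compound 2 to compound 4, 1.3-fold (0.12 log units) apart, within the scatter of two such steps. Among these compounds, all of these steps lie within the scatter, so the agreement shows only that neither change moved the number clearly on these cores, not that either has a real effect or that the same would hold on any other core.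

The compounds shown carry only fluoro or chloro on the sulfonyl aryl ring and only methyl or trifluoromethyl on the other substituted aryl ring. Going by these compounds, how an amine, a methoxy group or a carboxylic acid at either place would read remains open.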